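Piperazine in Place of a Glycinate Amine on a Bromo Core

The source may report more compounds than this note shows. Statements on the series, on what has been measured and on what is new or still open speak of the compounds shown alone.

Compound 1, `N[C@H]1CC[C@H](Nc2c(C(=O)NCc3ccc(Cl)cc3)nc(Br)c3cccnc23)CC1`, in a functional assay on SK-BR-3 cells (Homo sapiens) for cytotoxicity, read by MTT assay, with a stated time of 72 h (on this read-out higher numbers stand for weaker inhibition and lower numbers for stronger inhibition), gives compound 1 a value of 2000 nM.
Compound 2, `NCCCNc1c(C(=O)NCc2ccc(F)cc2)ncc2cccnc12`, reaches in this assay only a limit of the assay, > 10000 nM; it is a limit and not a number.
Compound 3, `COC(=O)CNc1c(C(=O)NCc2ccc(F)cc2)nc(Br)c2cccnc12`, gives in this assay 1000 nM.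

Of the two numbers shown, compound 3 sits at the low end, and compound 1 is its nearest neighbour, a gap that lies within the scatter of repeated measurements. The remaining value belongs to compound 2 and is a limit only (the limit of > 10000 nM in this assay, at which 1 of the 3 values shown sits).

Compound 4, `O=C(NCc1ccc(F)cc1)c1nc(Br)c2cccnc2c1N1CCNCC1`, has not yet been measured in this assay. It differs from compound 3 in one place: piperazin-1-yl in place of ((methoxycarbonyl)methyl)amino on an aromatic carbon. For the measured compounds named here, no measured pair shows a single change of this kind, so there is no step to lean on.

With only compound 3 and its neighbour compound 1 as a guide, compound 4 is expected to land near compound 3, and the step of a 1.5-fold higher number from compound 3 to compound 4 (0.18 log units; within the scatter) is estimated to stay within the scatter or to reach slightly weaker inhibition. Compound 4 is therefore expected to give about 1500 nM, with a range from 400 nM to 6000 nM.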

Compound 4, half-maximal inhibitory concentration: 6000 nM
The estimate for compound 4 lay 4.0-fold (0.60 log units) below the measured number, and the stated range covers the measured number.
By their numbers in this assay, from the lowest: compounds 3 and 1 (each within the scatter of the next); then compound 4. At a limit, above all of these: compound 2.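

For the compounds shown here, at this position, on an aromatic carbon para to a bromo group, the replacement of ((methoxycarbonyl)methyl)amino by piperazin-1-yl gives the first change in a single place that can be read in this assay: a 6.0-fold higher number from compound 3 to compound 4 (0.78 log units; beyond the scatter). The two groups match in heavy atoms, at 6 each, and neither has a net charge, so the step goes with a change from a group with no ring to a six-membered non-aromatic ring, not with a change in heavy-atom count. Nothing measured here gives a cause for this step.

Going by these compounds, it remains open whether the step follows the ring itself or the loss of the methoxycarbonyl group, and a morpholin-4-yl group or a carboxylic acid in place of the ester at this position would separate the two. On these data alone, it is also open whether a step of this size would hold on a core without the bromo group, as compound 2 has no bromo group but differs from compound 3 in more than one place.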